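Cytotoxicity notes: compound 2 to compound 3

This account rests on a few compounds, and the source may have more. Where it says the series, first, only, none or still open, it means among the compounds named here.

In an ADME assay on SH-SY5Y cells (Homo sapiens) for cytotoxicity, read by MTT assay, with a stated time of 72 h (a lower number here means a stronger inhibitor, a higher number a weaker inhibitor), compound 1 `O=C(CN1CCN(C(=O)c2ccc(Br)cc2)CC1)N1CCN(CCCc2c[nH]c3ccccc23)CC1` gives 59300 nM as its value. Compound 2 `Cc1ccc(C(=O)N2CCN(CC(=O)N3CCN(CCCc4c[nH]c5ccccc45)CC3)CC2)cc1` gives > 200000 nM here, which is a limit of the assay and not a number, so it stands at the limit of > 200000 nM in this assay, at which 1 of the 2 values shown sits, without an exact place. Going by the values given here, the only measured step is an at least 3.3-fold higher number from compound 1 to compound 2 (0.52 log units; beyond the scatter) with methyl in place of bromo on an aromatic carbon. Compound 3 `COc1cccc(C(=O)N2CCN(CC(=O)N3CCN(CCCc4c[nH]c5ccccc45)CC3)CC2)c1` differs by 3-methoxyphenyl in place of 4-methylphenyl on a carbonyl carbon and so has 3-methoxyphenyl in place of 4-methylphenyl on a carbonyl carbon. No bromo group returns, so no step beyond the scatter is expected in this assay from this change. The estimated shift is an at least 1.1-fold lower number from compound 2 to compound 3 (0.07 log units; that floor lies within the scatter) in size. For compound 3 the estimate is 170000 nM (expected range 80000 nM to 350000 nM).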

Compound 3, half-maximal inhibitory concentration: > 200000 nM
Compound 3 was reported as a limit (the forecaster's own chance of this, stated with the estimate: 55%); middle value at least 1.1-fold (0.07 log units) away from the limit.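

In this assay, exchanging 4-bromophenyl for 3-methoxyphenyl gives an at least 3.3-fold higher number from compound 1 to compound 3 (0.52 log units; beyond the scatter), so a higher number than that of compound 1 is no longer tied to 4-methylphenyl alone. Compound 3 gives a limit of the assay and not a number, and it joins compound 2 there: the limit of > 200000 nM in this assay, at which 2 of the 3 values shown sit.

The step between these two limits cannot be read, so any effect of the added oxygen remains unresolved. Open, going by these compounds, is whether 4-chlorophenyl or a carboxylic acid-bearing phenyl group on the same carbonyl carbon would give a number near that of compound 1 or stay at the limit.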